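The source may hold more compounds than are shown below. What is called first, only, known or untested is meant among the compounds shown, and "the series" means these compounds.

Measured so far in an ADME assay on Huh-7 cells (Homo sapiens) for cytotoxicity; on this read-out lower numbers stand for higher toxicity in this test and higher numbers for lower toxicity in this test:
compound 1, `Cc1ccccc1-c1nn(C(C)C)cc1CNCCN1CCN(C)CC1` — compound 1 gives > 20000 nM, which is a limit of the assay and not a number.
compound 2, `CCOC(=O)Cn1cc(CNCCN2CCN(C)CC2)c(-c2ccccc2C)n1` — compound 2 gives > 20000 nM, again only a limit of the assay.

Compound 2 therefore stands at the limit of this assay, with no numeric value; both values shown sit there, as noted in the limit of > 20000 nM in this assay, at which 2 of the 2 values shown sit. Going by the values given here, the single measured step, a step that the two limits leave unreadable from compound 1 to compound 2, is unreadable between the two limits and gives no size.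

The next member is compound 3, `Cc1ccccc1-c1nn(Cc2ccccc2)cc1CNCCN1CCN(C)CC1`, which differs from compound 2 by phenyl in place of ethoxycarbonyl on a saturated chain carbon bound to an aromatic nitrogen. Among the compounds with values here, the one measured step concerns the substituent on the same aromatic nitrogen and carries no readable size, so nothing bears usefully on this change. The step is expected to be none beyond the scatter, a step that the limit leaves unreadable from compound 2 to compound 3, with compound 3 most likely also reported only as a limit. The estimate for compound 3 in this assay is 30000 nM, in the range 10000 nM to 100000 nM.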

Compound 3, half-maximal cytotoxic concentration: > 20000 nM
Compound 3: no number, only a limit (the forecaster's own chance of this, stated with the estimate: 80%); the middle value lies beyond the limit too.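

Compound 3 joins compound 1 and compound 2 at a limit and not a number, so no step among the three can be read: the limit of > 20000 nM in this assay, at which 3 of the 3 values shown sit.

The compounds shown leave open whether any substituent on that aromatic nitrogen gives a numeric value in this assay.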